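This account rests on a few compounds, and the source may have more. Where it says the series, first, only, none or still open, it means among the compounds named here.

Measured so far:
- compound 1, `Cc1cc(-c2c(O)nc3cc(Cl)c([N+](=O)[O-])cc3c2OCCC2CCCCN2)cc(C(C)O)c1`: 63 nM
- compound 2, `O=C(Nc1cc2c(OCCC3CCCCN3)c(-c3cccc(Br)c3)c(O)nc2cc1Cl)NC1CC1`: 6 nM

Both compounds were tested in a functional assay on cells (Pituitary gland cell) for antagonist activity at Gonadotropin-releasing hormone receptor (Rattus norvegicus); a higher number here means a weaker inhibitor, a lower number a stronger inhibitor. Compound 1 gives 63 nM, the higher of the two numbers. Compound 2 gives 6 nM, and the gap between the two lies beyond the usual scatter of this assay, so compound 2 is clearly the stronger inhibitor. Compound 2 differs from compound 1 in more than one place, so no single change can be read from that pair.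

Compound 3, `O=[N+]([O-])c1cc2c(OCCC3CCCCN3)c(-c3cc(Cl)cc(Cl)c3)c(O)nc2cc1Cl`, has not yet been measured. It differs from compound 1 in one place: 3,5-dichlorophenyl in place of 3-(1-hydroxyethyl)-5-methylphenyl on an aromatic carbon. Among the measured compounds shown here, no measured pair shows this same change on its own, so any expectation rests on the two numbers above and on the nature of the swap. For the measured compounds named here, the only other compound that carries a halogenated phenyl ring at this position, compound 2, gives 6 nM, although it also carries other changes. On that basis a moderate move toward a lower number is expected for compound 3, of roughly a 2.1-fold lower number from compound 1 to compound 3 (0.32 log units; beyond the scatter), which may still sit near the edge of the scatter. Compound 3 is estimated at 30 nM, with a range of 8 nM to 120 nM.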

Compound 3, half-maximal inhibitory concentration: 24 nM
Compound 3: the middle estimate sits 1.3-fold (0.10 log units) above what was measured, within the range that was stated.
By their numbers in this assay, from the lowest: compound 2; then compound 3; then compound 1.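

In this assay, putting 3,5-dichlorophenyl in place of 3-(1-hydroxyethyl)-5-methylphenyl gives a 2.6-fold lower number from compound 1 to compound 3 (0.42 log units; beyond the scatter), the first change in a single place among these compounds, and it shows that the group on this aromatic carbon, ortho to the 2-(piperidin-2-yl)ethoxy group and ortho to the hydroxy group, affects the result. The group that leaves has 1 hydrogen-bond donor and 1 hydrogen-bond acceptor and the group that enters has 0 of each, so in this pair an aryl group without them still gives the lower number. No measurement here explains the step, and the swap replaces both ring substituents at once, so the shift cannot be divided between them.

From the compounds shown here alone, it remains open whether the chlorines, the loss of the 1-hydroxyethyl group or the loss of the methyl group accounts for the step, and how a ring with only one chlorine, or one carrying an amine or a carboxylic acid, would behave here. Compound 2 differs from the other two compounds in more than one place, so its number cannot be tied to the aryl group alone.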